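The compounds below may be only part of what the source reports. "The series", "measured", "known", "first", "only" and "open" are said of these compounds alone.

Measured in a functional assay on MCF7 cells (Homo sapiens) for antiproliferative activity, read by MTT assay, with a stated time of 24 h; a higher number here means a weaker inhibitor, a lower number a stronger inhibitor:
- Compound 1 `CNC(=O)c1ccccc1Oc1nc(Nc2ccc(Br)cc2)ncc1Br`: > 50000 nM, which is a limit and not a number.
- Compound 2 `CNC(=O)c1ccccc1Oc1nc(Nc2cccc(C)c2)ncc1Br`: 16600 nM
- Compound 3 `CNC(=O)c1ccccc1Oc1nc(Nc2cccc(C(F)(F)F)c2)ncc1Br`: 57800 nM

Compound 2 has the lower of the two true numbers, and compound 3 is its nearest neighbour. Compound 4 `CCOc1ccccc1Oc1nc(Nc2cccc(C)c2)ncc1Br` keeps the rest of compound 2 but carries ethoxy in place of methylcarbamoyl on an aromatic carbon. For the measured compounds named here, no measured step touches this group. The closest guides are changes made elsewhere on the molecule: an at least 3.0-fold lower number from compound 1 to compound 2 (0.47 log units; beyond the scatter) and a 3.5-fold higher number from compound 2 to compound 3 (0.54 log units; beyond the scatter). Both were modest or somewhat more, so a step of similar size is a reasonable expectation in this assay. Going by the values given here, the direction is uncertain, but a rise is more likely, as the only other true number, for compound 3 at 57800 nM, lies higher. The expected step is a 2.1-fold higher number from compound 2 to compound 4 (0.32 log units; beyond the scatter). For compound 4 the estimated value is 35000 nM, with an expected range of 10000 nM to 100000 nM.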

Compound 4, half-maximal inhibitory concentration: 39100 nM
The estimate for compound 4 lay 1.1-fold (0.05 log units) below the measured number; the measured number falls inside the stated range.
By their numbers in this assay, from the lowest: compound 2; then compounds 4 and 3 (each within the scatter of the next).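

Swapping methylcarbamoyl, which has a hydrogen-bond donor, for ethoxy, which has none, gives a 2.4-fold higher number from compound 2 to compound 4 (0.37 log units; beyond the scatter) and is the only change shown at this place on the aromatic ring. In this assay, the two groups are therefore not interchangeable here, though the step is modest. Compound 1 has a limit and not a number: the limit of > 50000 nM in this assay, at which 1 of the 4 values shown sits.

A single swap cannot show whether the donor matters or some other difference between the groups. A methoxy group, a primary amide or a carboxylic acid at this place could help to separate these possibilities.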